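Swapping a cyclopentyl for a phenyl on the shared core

This account rests on a few compounds, and the source may have more. Where it says the series, first, only, none or still open, it means among the compounds named here.

Of the compounds shown here, three of one shared core have been tested in an assay on cells for displacement of a labelled ligand from adenosine receptor A1 (Homo sapiens), with a stated time of 60 min, tested at 1 uM; a lower number here means less inhibition, a higher number more inhibition at the concentration tested (going by the name of the read-out). Compound 1 `CC1=C(C(=O)OC(C)C)C(C2CCCC2)N/C(=N/C#N)N1` gives 3%. Compound 2 `CC1=C(C(=O)OC(C)C)[C@@H](c2ccco2)N/C(=N/C#N)N1` gives 2%, a number within the usual scatter of that of compound 1. Compound 3 `CCOC(=O)C1=C(C)N/C(=N\C#N)NC1c1ccco1` gives 27%, a number clearly higher than that of compound 1, beyond the scatter. Compound 4 `CC1=C(C(=O)OC(C)C)C(c2ccccc2)N/C(=N/C#N)N1` has not yet been measured in this assay. It differs from compound 1 in one place: phenyl in place of cyclopentyl on a saturated ring carbon. Among the measured compounds shown here, no measured pair shows the effect of this change, so the expected step from compound 1 to compound 4 is taken as small, a number 3 percentage points higher from compound 1 to compound 4 (within the scatter), not beyond the scatter. Compound 4 is therefore estimated to give about 6%, within a range from 0% to 20%.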

Compound 4, a percentage reported as inhibition, at one concentration (the size of the read-out at that concentration, not a potency): 20%
Compound 4: middle estimate off by 14 percentage points, on the low side; measured number inside the range.
By their numbers in this assay, from the lowest: compounds 2 and 1 (each within the scatter of the next); then compounds 4 and 3 (each within the scatter of the next).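

At this saturated ring carbon of the shared core, the choice of ring matters in this assay: phenyl in place of cyclopentyl gives a number 17 percentage points higher from compound 1 to compound 4 (beyond the scatter). Among the compounds shown here, this is the first one-place comparison at this position, and it shows that the position responds to a change of ring. No measurement at hand explains the step.

Still open, going by these compounds, is how a phenyl ring bearing an amine or a carboxylic acid, or a longer chain such as benzyl, would read at this carbon. Also open, on these data alone, is whether the same swap gives a similar step with a different ester on the shared core.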